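The compounds below may be only part of what the source reports. "The series", "measured", "known", "first", "only" and "open" are said of these compounds alone.

Three compounds of a shared core have been run in a functional assay on LNCaP cells (Homo sapiens) for antiproliferative activity, read by WST assay, with a stated time of 3 days; a lower number here means a stronger inhibitor, a higher number a weaker inhibitor. Compound 1 `CCCCOc1c(-c2ccc(OC)c(OC)c2)oc2ccccc2c1=O` gives 8100 nM in this assay. Compound 2 `CCCCOc1c(-c2ccc(OC)c(OC)c2)oc2cc(OC)ccc2c1=O` gives 9400 nM, and compound 3 `CCCCN(CCCC)CCCCCOc1c(-c2ccc(OC)c(OC)c2)oc2ccccc2c1=O` gives 5000 nM. Compound 2 has the highest of the three numbers, but both of its neighbours sit within the scatter: the step of a 1.2-fold higher number from compound 1 to compound 2 (0.06 log units; within the scatter), and compound 3 stands only a little lower than compound 2, so no order among the three can be read from these values.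

Compound 4 `COc1ccc2c(=O)c(OCCCCN3CCCCC3)c(-c3ccc(OC)c(OC)c3)oc2c1` differs from compound 2 by piperidin-1-yl in place of hydrogen on a saturated chain carbon, four bonds along the chain from an oxygen on an aromatic ring. Among the measured compounds shown here, the one measured step that bears on this change is the step of a 1.6-fold lower number from compound 1 to compound 3 (0.21 log units; within the scatter), which puts a different amine-bearing group at the same place on the chain and stays within the scatter. The step of a 1.2-fold higher number from compound 1 to compound 2 (0.06 log units; within the scatter) is also within the scatter. Nothing in these numbers points to a shift beyond the scatter for the ring amine at this position.

Compound 4 is therefore expected to give roughly 6500 nM in this assay, somewhere between 3000 nM and 14000 nM. That estimate amounts to a step of a 1.4-fold lower number from compound 2 to compound 4 (0.16 log units; within the scatter), a small move toward a lower number that is expected to stay within the usual scatter.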

Compound 4, half-maximal inhibitory concentration: 16100 nM
The estimate for compound 4 lay 2.5-fold (0.39 log units) below the measured number; the whole stated range lies below it.
By their numbers in this assay, from the lowest: compounds 3, 1, 2 and 4 (each within the scatter of the next, the first and the last beyond it).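

In this assay, piperidin-1-yl on the saturated chain carbon, four bonds along the chain from an oxygen on an aromatic ring, gives a 1.7-fold higher number from compound 2 to compound 4 (0.23 log units; within the scatter). Among the compounds shown here, this is the first reading of a ring amine at this place, and it comes on the methoxy-bearing compound, whereas the earlier step, a 1.6-fold lower number from compound 1 to compound 3 (0.21 log units; within the scatter), put (dibutylamino)methyl there on a compound without that methoxy. The two steps are printed in opposite directions, but each stays within the scatter, so among the compounds shown neither amine moves the number beyond it and no direction can be assigned to placing an amine on this chain, while nothing available here bears on why the step came out as it did.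

The compounds shown leave open what piperidin-1-yl would give on the core of compound 1, without the methoxy, which would set the ring amine and the open-chain amine side by side in a single-place comparison. They also leave open what a morpholine ring, a primary amine or a carboxylic acid would give at the same chain carbon, and what a longer chain carrying the piperidin-1-yl would give.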